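Series notes: compound 4 as a variant of compound 1

The source may report more compounds than this note shows. Statements on the series, on what has been measured and on what is new or still open speak of the compounds shown alone.

Measured compounds:
compound 1 `Cc1ccc2[nH]c(-n3[nH]c(C)c(Cc4ccccc4)c3=O)nc2c1` — 35%
compound 2 `Cc1ccc2[nH]c(-n3[nH]c(C)c(C)c3=O)nc2c1` — -11%
compound 3 `Cc1nn(-c2nc3ccccc3[nH]2)c(O)c1Cc1ccccc1` — 42%

In a functional assay on DU-145 cells (Homo sapiens) for antiproliferative activity, read by WST assay, with a stated time of 48 h, tested at 1 uM (on this read-out lower numbers stand for a weaker effect and higher numbers for a stronger effect at the one concentration tested), compound 1 gives 35%, the second highest of the three numbers. Compound 3 gives 42%, and the gap to compound 1 lies within the scatter, so the two cannot be ordered. Going by the values given here, compound 2 gives -11%; the one step measured runs a number 46 percentage points lower from compound 1 to compound 2 (beyond the scatter), for hydrogen in place of phenyl on a saturated chain carbon bound to an aromatic carbon, a large loss.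

Compound 4 `Cc1[nH]n(-c2nc3cc(-c4ccc(Cl)cc4)ccc3[nH]2)c(=O)c1Cc1ccccc1` keeps that phenyl and changes a different place: 4-chlorophenyl in place of methyl on an aromatic carbon. Among the compounds with values here, the measured step does not bear on this position, and no measured pair changes a group on the fused ring, so there is no direct guide for this assay. What is known is only that the benzyl-bearing side of the core carries the effect in compound 1 and compound 3, and that side is unchanged in compound 4. The step is therefore expected to be small, as a number 7 percentage points higher from compound 1 to compound 4 (within the scatter), possibly none beyond the scatter, with a wide range.

Compound 4 is estimated at 42%, between 15% and 68%.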

Compound 4, a percentage reported as inhibition, at one concentration (the size of the read-out at that concentration, not a potency): 70%
Beside the measured number, compound 4's estimate is 28 percentage points below it; measured number above the stated range.
By their numbers in this assay, from the lowest: compound 2; then compounds 1 and 3 (each within the scatter of the next); then compound 4.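

In this assay, going by these compounds alone, 4-chlorophenyl in place of methyl on an aromatic carbon gives a number 35 percentage points higher from compound 1 to compound 4 (beyond the scatter), so this position, where no earlier pair had changed a group, clearly responds to substitution. Together with a number 46 percentage points lower from compound 1 to compound 2 (beyond the scatter), this shows that the read-out in this series depends on at least two separate places on compound 1, not only on the phenyl on the saturated chain. The larger group, with its added six-membered aromatic ring and chlorine, is tolerated here and goes with a stronger effect at the one concentration tested, but nothing available explains the gain.

Open, as far as these compounds go, is how a plain phenyl, a lone chlorine, a methoxy group or an amine on this aromatic carbon would compare with 4-chlorophenyl, a comparison that would separate the contribution of the added ring from that of the chlorine. Also open, from the compounds shown here alone, is whether the gain persists with hydrogen in place of the phenyl on the saturated chain, which would show whether the two places act independently.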